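The source may hold more compounds than are shown below. What is called first, only, known or untested is meant among the compounds shown, and "the series" means these compounds.

Working notes on the series.

Three compounds carry the same fused core with a chloromethyl-substituted benzyl arm and have been run in a functional assay on CAKI-1 cells (Homo sapiens) for cytotoxicity, read by sulforhodamine B assay, with a stated time of 48 h; a lower number here means a stronger inhibitor of growth, a higher number a weaker inhibitor of growth. Compound 1 `ClCc1ccccc1Cn1cnc2c(Cl)ncnc21` gives 4170 nM. Compound 2 `ClCc1cccc(Cn2cnc3ncnc(Cl)c32)c1` gives 4070 nM. Compound 3 `ClCc1cccc(Cn2cnc3c(Cl)ncnc32)c1` gives 2950 nM. The number for compound 3 is the smallest of the three, but its gaps to compound 2 and to compound 1 are both within the scatter, so the three values are read as one level rather than as a ranking.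

Compound 4 `ClCc1cccc(Cn2cnc3c(Cl)nc(Cl)nc32)c1` has not been measured. It differs from compound 3 in one place: chloro in place of hydrogen on an aromatic carbon. Among the measured compounds shown here, no pair of measured compounds differs by a change of this kind, so there is no measured step to lean on. For the measured compounds named here, the only guide is the flat picture across compound 1, compound 2 and compound 3 in this assay, which gives no sign that single substituent changes on this core move the value far.

The expectation is therefore a small step, at most at the edge of the scatter, leaning toward a somewhat lower number, as a 1.5-fold lower number from compound 3 to compound 4 (0.17 log units; within the scatter). Compound 4 is estimated at 2000 nM in this assay, with a range from 700 nM to 6000 nM.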

Compound 4, concentration for total growth inhibition: 5880 nM
Compound 4: the middle estimate sits 2.9-fold (0.47 log units) below what was measured; measured number inside the range.
By their numbers in this assay, from the lowest: compounds 3, 2, 1 and 4 (each within the scatter of the next).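

Among the compounds shown here, compound 4 supplies the first measured single-place step: in this assay, chloro in place of hydrogen on an aromatic carbon, between two ring nitrogen atoms, gives a 2.0-fold higher number from compound 3 to compound 4 (0.30 log units; within the scatter). This position therefore carries a chloro group with the value still within the scatter of compound 3, so the step gives no sign that this exchange separates the two compounds, and the four compounds read as one level. No measured property or other supporting data bears on this step, so it stands as an observation without an explanation.

The compounds shown compare only hydrogen and chloro at this position, so it remains open whether an amine, a methoxy group or a longer chain such as butyl there would stay at the same level or move clearly away from it. For the compounds shown here, it also remains open whether the same exchange would stay within the scatter on the arrangement of compound 1 or compound 2, since the only step available rests on the single pair of compound 3 and compound 4.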